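This account rests on a few compounds, and the source may have more. Where it says the series, first, only, none or still open, it means among the compounds named here.

Working notes on the series.

Compound 3, `NS(=O)(=O)c1cccc(Nc2nccc(-c3ccccn3)n2)c1`, is the reference point for the next step. Among the measured compounds shown here, in a functional assay for inhibition, with Homo sapiens as the target (a lower number here means a stronger inhibitor, a higher number a weaker inhibitor), compound 3 gives 500 nM, the lowest of the three numbers so far. Compound 2, `Cc1cccc(Nc2nccc(-c3ccncc3)n2)c1`, gives 8800 nM, and compound 1, `CCc1cccc(Nc2nccc(-c3ccncc3)n2)c1`, gives 10600 nM; both stand well beyond the scatter from compound 3. For the measured compounds named here, the only measured step, a 1.2-fold lower number from compound 1 to compound 2 (0.08 log units; within the scatter), concerns a change on the saturated chain carbon and says nothing about the aromatic ring carried on the shared core.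

Compound 4, `NS(=O)(=O)c1cccc(Nc2nccc(-c3ccncc3)n2)c1`, differs from compound 3 by pyridin-4-yl in place of pyridin-2-yl on an aromatic carbon. Going by the values given here, no measured step bears on this change: compounds 1 and 2 carry pyridin-4-yl as compound 4 does, but they differ from compound 3 at a second place as well, so their values cannot be read as the effect of this change alone. The expected step is therefore a 1.6-fold higher number from compound 3 to compound 4 (0.20 log units; within the scatter), with a wide range in either direction. Compound 4 is estimated at 800 nM, between 200 nM and 4000 nM.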

Compound 4, half-maximal inhibitory concentration: 500 nM
The estimate for compound 4 lay 1.6-fold (0.20 log units) above the measured number, within the range that was stated.
By their numbers in this assay, from the lowest: compounds 3 and 4 (each within the scatter of the next); then compounds 2 and 1 (each within the scatter of the next).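

With sulfamoyl present, pyridin-4-yl in place of pyridin-2-yl gives no change at the digits printed from compound 3 to compound 4 (within the scatter) in this assay, so this position does not separate these two pyridinyl groups. Among the compounds shown here, with pyridin-4-yl held constant, sulfamoyl in place of methyl gives an 18-fold lower number from compound 2 to compound 4 (1.25 log units; beyond the scatter), and sulfamoyl in place of ethyl gives a 21-fold lower number from compound 1 to compound 4 (1.33 log units; beyond the scatter); the large gap between the earlier compounds therefore tracks the sulfamoyl swap, not the pyridinyl change. No supporting data bear on why either change has the effect it does.

On these data alone, whether pyridin-2-yl and pyridin-4-yl also match when methyl or ethyl replaces sulfamoyl remains open. As far as these compounds go, it is also open how pyridin-3-yl would behave at this position, and whether a carboxylic acid or an amine in place of sulfamoyl would keep the number as low.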